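Triazole-linked series: adding a second chloro on the aryl ring

The compounds below may be only part of what the source reports. "The series", "measured", "known", "first", "only" and "open" are said of these compounds alone.

Of the compounds shown here, two have numbers so far. Compound 1 `Cc1cn([C@H]2C[C@H](NC(=S)Nc3ccc(Cl)c(C(F)(F)F)c3)[C@@H](CO)O2)c(=O)[nH]c1=O` gives in an assay on isolated protein for inhibition of thymidine kinase, cytosolic (Homo sapiens), read by scintillation counting, with a stated time of 30 min (on this read-out lower numbers stand for stronger inhibition and higher numbers for weaker inhibition), a value of 316000 nM. Compound 2 `Cc1cn([C@H]2C[C@H](n3cc(-c4ccc(Cl)cc4)nn3)[C@@H](CO)O2)c(=O)[nH]c1=O` gives in this assay a value of 71000 nM, the lowest of the two numbers; its gap to compound 1 lies beyond the scatter.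

Compound 3 `Cc1cn([C@H]2C[C@H](n3cc(-c4ccc(Cl)c(Cl)c4)nn3)[C@@H](CO)O2)c(=O)[nH]c1=O` is not yet measured. Relative to compound 2 the difference is chloro in place of hydrogen on an aromatic carbon, in words chloro in place of hydrogen on an aromatic carbon. Within the data shown here, no measured pair shows this change, so no step for it is known. The expectation is a modest lowering of the number, at the edge of the scatter, with a null step equally plausible. The step this estimate means in this assay is a 1.6-fold lower number from compound 2 to compound 3 (0.20 log units; within the scatter). For compound 3 the expected value in this assay is 45000 nM, with a range from 15000 nM to 140000 nM.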

Compound 3, half-maximal inhibitory concentration: 75000 nM
Estimate against measurement, compound 3: 1.7-fold (0.22 log units) below, within the range that was stated.
By their numbers in this assay, from the lowest: compounds 2 and 3 (each within the scatter of the next); then compound 1.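

In this assay, the change from 4-chlorophenyl to 3,4-dichlorophenyl gives a 1.1-fold higher number from compound 2 to compound 3 (0.02 log units; within the scatter), so a chloro ortho to a chloro group and meta to a large group is accepted on this ring without a readable shift in the number. Among these compounds, this is the only measured step for this change, and as a single pair it describes this one position on this one aryl ring. No further data bear on this result.

From the compounds shown here alone, whether a different group at this position, such as a methoxy, an amine or a carboxylic acid, would move the number remains open. Also open, going by these compounds, is whether this chloro would give the same step on a ring that lacks the existing chloro group.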